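Swapping a dichlorophenyl ether for a fluorobenzylamine

This account rests on a few compounds, and the source may have more. Where it says the series, first, only, none or still open, it means among the compounds named here.

Compound 1 `Nc1cc(N)c2nc(-c3ccccc3)c(Oc3ccc(Cl)c(Cl)c3)nc2c1` was tested in a functional assay on SW-620 cells (Homo sapiens) for inhibition, read by sulforhodamine B assay, with a stated time of 48 h (a higher number here means a weaker inhibitor of growth, a lower number a stronger inhibitor of growth), where it gave 30200 nM. Within this small set, compound 1 is the only compound with a definite number. Compound 2 `CCOC(=O)[C@H](CCC(=O)O)NC(=O)c1ccc(CNc2nc3cc(N)cc(N)c3nc2-c2ccccc2)cc1` gave only a limit of the assay, < 100000 nM, and not a number. Compound 3 `CCOC(=O)[C@H](CCC(=O)O)NC(=O)c1ccc(Oc2nc3cc(N)cc(N)c3nc2-c2ccccc2)cc1` likewise gave only a limit, < 100000 nM. The two larger compounds thus stand at the same limit, and only compound 1 offers a number to build on.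

Compound 4 `Nc1cc(N)c2nc(-c3ccccc3)c(NCc3ccc(F)cc3)nc2c1` differs from compound 1 in one place: (4-fluorobenzyl)amino in place of 3,4-dichlorophenoxy on an aromatic carbon. Among the compounds with values here, no pair of measured compounds in this set shows that same change, so the size of the step has no measured precedent here. The two larger compounds sit at a limit because the limit of < 100000 nM in this assay, at which 2 of the 3 values shown sit, is where their values fall, which gives no direction for the new compound.

With nothing in the data pointing clearly either way, compound 4 is expected to stay close to compound 1, and the step of a 1.3-fold higher number from compound 1 to compound 4 (0.12 log units; within the scatter) is expected to lie within the usual scatter. Compound 4 is estimated at 40000 nM, with a range from 10000 nM to 100000 nM.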

Compound 4, concentration for total growth inhibition: 9550 nM
Compound 4: middle estimate off by 4.2-fold (0.62 log units), on the high side; the measured number lies below the stated range.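

In this assay, replacing 3,4-dichlorophenoxy with (4-fluorobenzyl)amino on the aromatic carbon next to the ring nitrogen gives a 3.2-fold lower number from compound 1 to compound 4 (0.50 log units; beyond the scatter), a modest step but the first measured one at this position. It shows that growth inhibition in these cells responds to the group at this carbon, and that the dichlorophenyl ether is not needed to keep it, since the amine-linked group gives the lower number. The two groups have the same number of heavy atoms and each carries one six-membered aromatic ring of carbon only, yet they differ in the linking atoms, in the halogens and in the hydrogen-bond donor that enters, and no measurement here says which of these differences accounts for the step.

From the compounds shown here alone, what stays open is how these differences divide the effect, which a plain benzylamino group with no fluorine or a 3,4-dichlorobenzylamino group would help to separate. A direct anilino link or a longer chain between the nitrogen and the ring would show whether the distance to the aromatic ring matters at this position.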